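Dichlorobenzyl to butyl on a guanine-derived series

The source may hold more compounds than are shown below. What is called first, only, known or untested is meant among the compounds shown, and "the series" means these compounds.

Working notes on the series. Compound 1 `Nc1nc(O)c2c(n1)n(C1OC(CO)[C@@H](O)[C@H]1O)c(=O)n2Cc1ccc(Cl)c(Cl)c1` carries the ribose on its core together with a 3,4-dichlorobenzyl group. Going by the values given here, in a functional assay on the whole organism (B cells) with Mus musculus as the target (on this read-out lower numbers stand for smaller maximal responses and higher numbers for larger maximal responses), compound 1 gives 55%, the lowest of the three numbers measured so far. Compound 3 `C=CCn1c(=O)n(CCCC)c2nc(N)nc(O)c21` replaces the ribose with an allyl chain and the benzyl group with a butyl chain; in this assay compound 3 gives 77%, a number beyond the scatter above compound 1. Compound 2 `CCCn1c(=O)n(C2C=CC(CO)O2)c2nc(N)nc(O)c21` has a propyl chain and a dideoxy-type sugar; in this assay compound 2 gives 118%, the furthest from compound 1 and also beyond the scatter. Among the compounds with values here, no pair differing in only one place has been measured, so no single step is known.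

Compound 4 `CCCCn1c(=O)n(C2OC(CO)[C@@H](O)[C@H]2O)c2nc(N)nc(O)c21` is not yet measured. It differs from compound 1 in one place:

propyl in place of 3,4-dichlorophenyl on a saturated chain carbon bound to an aromatic nitrogen

The two compounds that carry only plain chains, compound 2 and compound 3, both give higher maximal responses than compound 1; this is an observation on two compounds and not a rule, and compound 2 differs from compound 1 in more than this place. On this basis an increase beyond the scatter is expected in this assay, the step from compound 1 to compound 4 estimated at a number 30 percentage points higher from compound 1 to compound 4 (beyond the scatter). For compound 4 the estimate in this assay is 85%, expected to lie between 60% and 115%.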

Compound 4, largest response reached (reported as maximal response), in percent of the reference or control that the assay uses: 86%
Compound 4: middle estimate off by 1 percentage points, on the low side; the measured number falls inside the stated range.
By their numbers in this assay, from the lowest: compound 1; then compounds 3 and 4 (each within the scatter of the next); then compound 2.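

In this assay, going by these compounds alone, 3,4-dichlorobenzyl to butyl with the ribose kept in place gives the first single step: a number 31 percentage points higher from compound 1 to compound 4 (beyond the scatter). Within the data shown here, the earlier compounds differed from one another in more than one place, so this is the first size that can be given to a change at this position alone, on a saturated chain carbon bound to an aromatic nitrogen. The maximal response is therefore sensitive to the group held here, and a plain chain in place of the 3,4-dichlorophenyl goes with the larger number, although this single step cannot separate the loss of the aromatic ring from the loss of the chlorine atoms.

No measurement on hand accounts for the size or direction of the step. Still open, going by these compounds, is where an unsubstituted benzyl, a 4-chlorobenzyl, a hexyl chain or a butyl chain ending in an amine would fall on this read-out, and whether the same step would hold on a core carrying something other than the ribose.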